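From compound 3 to compound 4: adding a methoxy

A few compounds are considered here, and "the series" means these few. Any claim that something is new, unique, unknown or untested is made for them only; others in the source may bear on it.

In a functional assay on HCT-116 cells (Homo sapiens) for cytotoxicity, read by MTT assay, with a stated time of 72 h (on this read-out lower numbers stand for stronger inhibition and higher numbers for weaker inhibition), compound 3 (`O=S(=O)(c1ccccc1)c1nc2ccccc2nc1N1CCc2ccccc2C1`) gives 18700 nM. Compound 2 (`O=S(=O)(c1ccc(Br)cc1)c1nc2ccccc2nc1N1CCCC1`) gives 37700 nM, and these two values lie within the scatter of each other. Compound 1 (`Cc1ccc(S(=O)(=O)c2nc3ccccc3nc2N2CCCC2)cc1`) reads > 50000 nM, which is a limit of this assay. Compound 4 (`COc1ccc(S(=O)(=O)c2nc3ccccc3nc2N2CCc3ccccc3C2)cc1`) differs from compound 3 by methoxy in place of hydrogen on an aromatic carbon, with methoxy in place of hydrogen on an aromatic carbon. Going by the values given here, the only measured step, an at least 1.3-fold lower number from compound 1 to compound 2 (0.12 log units; that floor lies within the scatter), exchanges methyl for bromo on an aromatic carbon, and no measured step adds a methoxy. No change beyond the scatter is therefore expected, and the estimated step is a 1.2-fold higher number from compound 3 to compound 4 (0.07 log units; within the scatter). The estimate for compound 4 is 22000 nM, with an expected range of 9000 nM to 50000 nM.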

Compound 4, half-maximal inhibitory concentration: 22100 nM
Compound 4: middle estimate off by 1.0-fold (0.00 log units), on the low side; measured number inside the range.
By their numbers in this assay, from the lowest: compounds 3, 4 and 2 (each within the scatter of the next). At a limit, above all of these: compound 1.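

In this assay, the change from phenyl to 4-methoxyphenyl, on an aromatic carbon para to a large group, stays within the scatter (a 1.2-fold higher number from compound 3 to compound 4 (0.07 log units; within the scatter)). Unlike the earlier step, which has a limit at one end, this one joins two measured numbers, so this place accepts a methoxy with no readable change. No measurement shown bears on a cause for this step. Going by these compounds, whether an amine or a carboxylic acid at this place would give a step beyond the scatter stays open. So does whether methoxy reads the same on the core of compound 1.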